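The source may report more compounds than this note shows. Statements on the series, on what has been measured and on what is new or still open speak of the compounds shown alone.

Of the compounds shown here, two built on the same core have been measured in a functional assay on cells (Lymphocyte), read by a luciferase reporter and ATP content, with a stated time of 48 h, tested at 5 uM; a lower number here means a stronger effect, a higher number a weaker effect of the compound at the concentration tested. Compound 1, `CCCCCCCCCCCCCCCCCCCc1c(C)c(N(C)C)nc(C)c1O`, carries a long saturated chain, and in this assay compound 1 gives 106%. Compound 2, `CCCCCCCCCCCCCCCCc1nc(N(C)C)c(C)c(C)c1O`, differs from it in more than one place, and in this assay compound 2 gives 100%. Compound 1 stands at the higher of the two numbers, yet both values lie within the scatter of each other, so neither compound shows a clear effect at the concentration tested.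

Compound 3, `CCCCCCCCCCc1c(C)c(N(C)C)nc(C)c1O`, has not yet been measured. It differs from compound 1 in a single place: hydrogen in place of nonyl on a saturated chain carbon, ten or more bonds along the chain from an aromatic carbon. The same difference, cut one bond further out, reads decyl to methyl; the core itself is untouched.

Among the measured compounds shown here, both measured compounds sit near the level of no effect, and no measured step among them shows how the length of the chain matters. No change beyond the scatter is therefore expected, a number 6 percentage points lower from compound 1 to compound 3 (within the scatter). Compound 3 is estimated at 100%, with an expected range from 85% to 115%.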

Compound 3, a percentage reported as activity, at one concentration (the size of the read-out at that concentration, not a potency): 87%
Estimate against measurement, compound 3: 13 percentage points above; measured number inside the range.
By their numbers in this assay, from the lowest: compound 3; then compounds 2 and 1 (each within the scatter of the next).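

Cutting back the chain has a measurable effect in this assay: hydrogen in place of nonyl, on a saturated chain carbon, gives a number 19 percentage points lower from compound 1 to compound 3 (beyond the scatter) and is the first readable step in this series. The core is untouched and the pair differs in this one place, so the outer part of the chain matters to the read-out at the concentration tested, with compound 3 showing the stronger effect of the two. No separate measurement bears on how this step arises.

Two chain lengths on this core cannot show whether the effect grows steadily as the chain gets shorter or appears only below a certain length, so a chain of intermediate length or a shorter one such as butyl would be needed to tell these apart. From the compounds shown here alone, it also remains open whether the outer part of the chain matters through its length alone, a question that a chain of similar length ending in a carboxylic acid or an amine could help to address.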